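This account rests on a few compounds, and the source may have more. Where it says the series, first, only, none or still open, it means among the compounds named here.

Working notes on the shared core of compound 1 `Cc1ccc(NC(=O)Nc2cccc(CNc3nccnc3Cl)c2)cc1`. In a functional assay on T-24 cells (Homo sapiens) for antiproliferative activity, read by MTT assay, with a stated time of 48 h (a lower number here means a stronger inhibitor, a higher number a weaker inhibitor), compound 1 gives 9820 nM. Compound 2 `O=C(Nc1cccc(CNc2nccnc2Cl)c1)Nc1ccccc1F` gives 7450 nM in this assay, and a 1.3-fold lower number from compound 1 to compound 2 (0.12 log units; within the scatter). Compound 3 `O=C(Nc1cccc(CNc2nccnc2Cl)c1)NC1CCCC1` reaches only a limit in this assay, at > 40000 nM. Against that limit, an at least 4.0-fold higher number from compound 1 to compound 3 (0.60 log units; beyond the scatter) and an at least 5.3-fold higher number from compound 2 to compound 3 (0.72 log units; beyond the scatter), so compound 3 sits at the weak end of what has been measured. The next step goes to compound 4 `O=C(Nc1cccc(CNc2nccnc2Cl)c1)Nc1ccc(Cl)cc1Cl`, with 2,4-dichlorophenyl in place of cyclopentyl on an amide-type nitrogen. The two steps into cyclopentyl were at least modest and this change runs the opposite way, so a lowering of the number in this assay is expected, about an at least 5.7-fold lower number from compound 3 to compound 4 (0.75 log units; beyond the scatter). Compound 4 is expected to land near 7000 nM, between 2500 nM and 25000 nM.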

Compound 4, half-maximal inhibitory concentration: 5740 nM
Compound 4: middle estimate off by 1.2-fold (0.09 log units), on the high side, and the stated range covers the measured number.
By their numbers in this assay, from the lowest: compounds 4, 2 and 1 (each within the scatter of the next). At a limit, above all of these: compound 3.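

In this assay, a third substituted phenyl group now stands against cyclopentyl on the amide-type nitrogen, with 2,4-dichlorophenyl giving an at least 6.9-fold lower number from compound 3 to compound 4 (0.84 log units; beyond the scatter). Two chlorines on the phenyl ring do not separate this group from the earlier phenyl groups, as the steps read a 1.3-fold lower number from compound 2 to compound 4 (0.11 log units; within the scatter) and a 1.7-fold lower number from compound 1 to compound 4 (0.23 log units; within the scatter). The step out of cyclopentyl gives only a bound, as compound 3 is a limit and not a number: the limit of > 40000 nM in this assay, at which 1 of the 4 values shown sits.

Still open, from the compounds shown here alone, is how a carboxylic acid on the phenyl ring or a longer alkyl chain on this nitrogen would read. Going by these compounds, it is also open whether any phenyl substitution pattern moves the number beyond the scatter.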